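Methyl Analogue in a Tetrazolyl Quinolone Series

The source may report more compounds than this note shows. Statements on the series, on what has been measured and on what is new or still open speak of the compounds shown alone.

Measured so far in a functional assay on the whole organism (strain Sprague-Dawley) for inhibition, with Rattus norvegicus as the target; a higher number here means that more compound is needed for the effect, a lower number that less compound is needed:
compound 1 `O=c1c(-c2nn[nH]n2)c[nH]c2ccccc12`, a limit only, > 20 mg/kg
compound 2 `Cc1ccc2[nH]cc(-c3nn[nH]n3)c(=O)c2c1`, a limit only, > 25 mg/kg
compound 3 `CCc1ccc2c(=O)c(-c3nn[nH]n3)c[nH]c2c1`, a limit only, > 10 mg/kg

Compound 1 stands at a limit in this assay and nowhere else on the numbers shown. The alkyl steps a step that the two limits leave unreadable from compound 1 to compound 2 and a step that the two limits leave unreadable from compound 1 to compound 3 are unreadable in size because the values at the limit of > 10 mg/kg in this assay, at which 1 of the 3 values shown sits, the limit of > 20 mg/kg in this assay, at which 1 of the 3 values shown sits, and the limit of > 25 mg/kg in this assay, at which 1 of the 3 values shown sits, are limits, not numbers. Compound 4 `Cc1cccc2c(=O)c(-c3nn[nH]n3)c[nH]c12` differs from compound 1 by methyl in place of hydrogen on an aromatic carbon, the methyl entering ortho to a fused ring. Both measured alkyl steps bear on this change, and neither gives a readable size, so the expected step of a number no higher from compound 1 to compound 4 (the limit leaves the size open) is none beyond the scatter. Compound 4 is estimated at 20 mg/kg, range 10 mg/kg to 40 mg/kg, most probably reported again as a limit.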

Compound 4, minimum effective dose: > 10 mg/kg
Compound 4 ended at the assay's limit; the forecaster's own chance of this, stated with the estimate: 80%; the middle value is on the limit's open side.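

In this assay compound 4 gives > 10 mg/kg, a limit. Compound 1 also stands at a limit, so no step can be read between compound 1 and compound 4. The compounds shown leave open what effect, if any, a methyl or ethyl group on the shared core has in this assay.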